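Para-chloro isomer of the methylated indole acid

A few compounds are considered here, and "the series" means these few. Any claim that something is new, unique, unknown or untested is made for them only; others in the source may bear on it.

The shared core of compound 1, `Cn1c(-c2cccc(Cl)c2)cc2cc(CCC(=O)O)ccc21`, carries a 3-chlorophenyl on the five-membered ring and a propanoic acid chain on the benzo ring. In a functional assay on CHO cells for agonist activity at Free fatty acid receptor 1 (Homo sapiens), read by a luciferase reporter, with a stated time of 24 h (on this read-out lower numbers stand for an effect already at smaller amounts and higher numbers for an effect only at larger amounts of compound), compound 1 gives only a limit, > 10000 nM, and not a number. Compound 1 thus sits at the limit of the assay, as other compounds measured here also do: the limit of > 10000 nM in this assay, at which 1 of the 2 values shown sits. Compound 2, `O=C(O)CCc1ccc2[nH]c(-c3ccccc3C(F)(F)F)cc2c1`, differs in several places at once and in this assay compound 2 gives 1310 nM; no single-point step connects it to compound 1, so the two values are only shown side by side.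

Compound 3, `Cn1c(-c2ccc(Cl)cc2)cc2cc(CCC(=O)O)ccc21`, is the next compound to be measured. It differs from compound 1 as follows: 4-chlorophenyl in place of 3-chlorophenyl on an aromatic carbon. Among the measured compounds shown here, no step between measured compounds covers such a change, so its size can only be guessed. The expected step from compound 1 to compound 3 in this assay, a number no higher from compound 1 to compound 3 (the limit leaves the size open), is small and likely within the scatter, with a fair chance that compound 3 again reaches only the limit. For compound 3 the estimated value in this assay is 10000 nM, within 3000 nM to 30000 nM.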

Compound 3, half-maximal effective concentration: > 10000 nM
Compound 3: no number, only a limit (the forecaster's own chance of this, stated with the estimate: 60%); the middle value sits exactly at the limit.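

Compound 3, like compound 1, gives only a limit and not a number in this assay, so the step between them, 4-chlorophenyl in place of 3-chlorophenyl, cannot be read. Both compounds stand at the same limit: the limit of > 10000 nM in this assay, at which 2 of the 3 values shown sit.

The compounds shown leave open whether 3-chlorophenyl and 4-chlorophenyl differ at all on this core.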